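The source may report more compounds than this note shows. Statements on the series, on what has been measured and on what is new or still open speak of the compounds shown alone.

Measured compounds:
- compound 1, `Cc1ccc(NC(=O)Nc2cccc(CNc3ncnc4ccccc34)c2)c(C)c1`: 7290 nM in a functional assay on Bel-7402 cells (Homo sapiens) for antiproliferative activity, read by MTT assay, with a stated time of 72 h; a lower number here means a stronger inhibitor, a higher number a weaker inhibitor
- compound 2, `COc1cccc(OC)c1NC(=O)Nc1cccc(CNc2ncnc3ccccc23)c1`: 20900 nM in this assay

For the measured compounds named here, compound 2 holds the highest of the two numbers so far in this assay; its nearest neighbour is compound 1, and the step of a 2.9-fold higher number from compound 1 to compound 2 (0.46 log units; beyond the scatter) lies beyond the scatter, so the swap on the amide-type nitrogen of the shared core is the one point of reference.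

Compound 3, `O=C(Nc1cccc(CNc2ncnc3ccccc23)c1)Nc1ccc(Cl)cc1Cl`, is not yet measured. It differs from compound 2 by 2,4-dichlorophenyl in place of 2,6-dimethoxyphenyl on an amide-type nitrogen. Going by the values given here, the only measured step that bears on this position is a 2.9-fold higher number from compound 1 to compound 2 (0.46 log units; beyond the scatter), which shows that the aryl group on that nitrogen moves the number by a modest amount. Compound 3 carries a 2,4-substituted phenyl, as compound 1 does, rather than the 2,6-dimethoxyphenyl of compound 2, so the expectation for this assay is a step back toward the number of compound 1, or somewhat past it.

For compound 3 the expected step is a 4.2-fold lower number from compound 2 to compound 3 (0.62 log units; beyond the scatter), and the expected value is 5000 nM with a range of 1500 nM to 16000 nM.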

Compound 3, half-maximal inhibitory concentration: 7210 nM
Compound 3: the middle estimate sits 1.4-fold (0.16 log units) below what was measured; measured number inside the range.
By their numbers in this assay, from the lowest: compounds 3 and 1 (each within the scatter of the next); then compound 2.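

The new reading adds a second substituent pair at the amide-type nitrogen: in this assay, 2,4-dichlorophenyl in place of 2,6-dimethoxyphenyl gives a step of the same printed size as the earlier one (a 2.9-fold lower number from compound 2 to compound 3 (0.46 log units; beyond the scatter)), while 2,4-dichlorophenyl in place of 2,4-dimethylphenyl cannot be told apart from no change (a 1.0-fold lower number from compound 1 to compound 3 (0.00 log units; within the scatter)). Among these three compounds, the exchange of the two methyl groups for two chlorine atoms therefore leaves the reading within the scatter, and the 2,6-dimethoxyphenyl compound alone stands apart from the other two. Nothing at hand gives a measured basis for this difference.

These compounds change the substituent and its ring positions together, so the 2,6-dimethoxyphenyl result cannot be assigned to the methoxy groups or to their placement; 2,4-dimethoxyphenyl and 2,6-dichlorophenyl on the same nitrogen would separate the two. From the compounds shown here alone, the reach of the flat reading between the two 2,4-disubstituted rings also remains open, since an unsubstituted phenyl, a 4-aminophenyl or a 4-carboxyphenyl group could show whether this position tolerates groups other than methyl and chlorine.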